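The source may report more compounds than this note shows. Statements on the series, on what has been measured and on what is new or still open speak of the compounds shown alone.

In a functional assay on SH-SY5Y cells (Homo sapiens) for antagonist activity, read by cAMP accumulation (a lower number here means a less potent compound, a higher number a more potent compound, by a factor of ten per unit of this negative logarithm), compound 1 `CC(C)COc1ccc(Cc2ccc(NC3=NCCN3)cc2)cc1` gives 8.8 while compound 2 `CCCCCCOc1ccc(Cc2ccc(NC3=NCCN3)cc2)cc1` gives 8.2 and compound 3 `COCCOc1ccc(Cc2ccc(NC3=NCCN3)cc2)cc1` gives 8 on the same scale. Compound 3 cannot be told apart from compound 2 (a number 0.20 log units lower from compound 2 to compound 3 (within the scatter)) but falls clearly short of compound 1 (a number 0.80 log units lower from compound 1 to compound 3 (beyond the scatter)), and compound 2 does as well (a number 0.60 log units lower from compound 1 to compound 2 (beyond the scatter)). Compound 4 `c1cc(NC2=NCCN2)ccc1Cc1ccc(OC2CCOCC2)cc1` differs from compound 3 by oxan-4-yl in place of 2-methoxyethyl on an oxygen on an aromatic ring and reads as oxan-4-yl in place of 2-methoxyethyl on an oxygen on an aromatic ring. All three measured steps change the group on this same oxygen, yet none brings in a ring, so they offer only a rough guide to size: modest at most. Oxan-4-yl holds an oxygen just as 2-methoxyethyl does, so compound 3 (8) is taken as the reference, and the higher number of compound 1 (8.8) is not assumed to carry over. A small upward change is expected, and the estimated a number 0.20 log units higher from compound 3 to compound 4 (within the scatter) is not expected to exceed the scatter. For compound 4 the estimated value is 8.2 with an expected range from 7.6 to 8.8 for this read-out.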

Compound 4, negative logarithm of the antagonist equilibrium constant: 8.4
The estimate for compound 4 lay 0.20 log units below the measured number, and the stated range covers the measured number.
By their numbers in this assay, from the lowest: compounds 3, 2 and 4 (each within the scatter of the next, the first and the last beyond it); then compound 1.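

In this assay, compound 4 brings a six-membered non-aromatic ring onto the oxygen on an aromatic ring, and two groups that each hold an oxygen prove not to be interchangeable at this position, since the change from 2-methoxyethyl to oxan-4-yl gives (a number 0.40 log units higher from compound 3 to compound 4 (beyond the scatter)). The ring cannot be separated from the open hexyl chain (a number 0.20 log units higher from compound 2 to compound 4 (within the scatter)), and it does not reach the branched isobutyl group (a number 0.40 log units lower from compound 1 to compound 4 (beyond the scatter)), so compound 1 remains the most potent of the four. No measurement at hand accounts for any of these steps.

Cyclohexyl on the same oxygen would show whether the ring oxygen of oxan-4-yl contributes at all. On these data alone, how a smaller ring such as oxetan-3-yl or a ring amine such as piperidin-4-yl reads here also stays open.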